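Amino for Phenoxy: Expected Cytotoxicity of Compound 4

The source may hold more compounds than are shown below. What is called first, only, known or untested is meant among the compounds shown, and "the series" means these compounds.

Compound 1 `CCCOCCNc1nc(Oc2ccccc2)nc2[nH]c(=O)c(-c3ccc(F)cc3)cc12` was measured in an ADME assay on Huh-7 cells (Homo sapiens) for cytotoxicity, read by MTT assay, with a stated time of 4 h, at 37 degrees C (a higher number here means that more compound is tolerated, a lower number that less compound is tolerated), where it gave 79800 nM. Among the compounds with values here, of the three numbers so far, this is the lowest. Compound 2 `CCCOCCNc1nc(Nc2ccccc2)nc2c1cc(-c1c(Cl)cccc1Cl)c(=O)n2C` gave 84700 nM in this assay, a value within the scatter of compound 1. Compound 3 `COCCn1c(=O)c(-c2c(Cl)cccc2Cl)cc2c(N)nc(Nc3ccccc3)nc21` gave 241000 nM in this assay, beyond the scatter and the furthest from compound 1. Compound 4 `CCCOCCNc1nc(N)nc2[nH]c(=O)c(-c3ccc(F)cc3)cc12` has not yet been measured. It differs from compound 1 in one place: amino in place of phenoxy on an aromatic carbon. Within the data shown here, no pair of measured compounds isolates this change, so the expectation rests on the spread of the three values. In this assay the step of a 1.6-fold higher number from compound 1 to compound 4 (0.21 log units; within the scatter) is expected to be modest, toward more compound tolerated, and may stay within the scatter. Compound 4 is therefore estimated at 130000 nM, with a range from 60000 nM to 280000 nM.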

Compound 4, half-maximal cytotoxic concentration: 130000 nM
The estimate for compound 4 equals the measured number at the digits printed, within the range that was stated.
By their numbers in this assay, from the lowest: compounds 1, 2, 4 and 3 (each within the scatter of the next, the first and the last beyond it).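

Amino in place of phenoxy on the aromatic carbon between two ring nitrogen atoms gives the first one-place comparison in this assay, and the step is a 1.6-fold higher number from compound 1 to compound 4 (0.21 log units; within the scatter) here. At this position, the six-membered aromatic ring of phenoxy can therefore leave without the number moving beyond the scatter. No measurement shown gives a reason for this outcome.

Open, going by these compounds, is how a methoxy group, a methylamino group or a morpholine ring at this carbon would read, and whether other groups there would stay within the scatter of compound 1 .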